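The source may report more compounds than this note shows. Statements on the series, on what has been measured and on what is new or still open speak of the compounds shown alone.

In a functional assay on A549 cells (Homo sapiens) for inhibition, read by MTT assay, with a stated time of 48 h (on this read-out lower numbers stand for stronger inhibition and higher numbers for weaker inhibition), compound 3 `COc1cc(/C=N/Nc2nc(-c3cccc(Br)c3)cs2)c(Br)c(Br)c1OC` gives 37000 nM and compound 1 `COc1cc(/C=N/Nc2nc(-c3cccc(Br)c3)cs2)cc(Br)c1OC` gives 56000 nM. The two differ by hydrogen in place of bromo on an aromatic carbon, a change that made a 1.5-fold higher number from compound 3 to compound 1 (0.18 log units; within the scatter). Compound 2 `Fc1ccc(/C=N/Nc2nc(-c3ccc(Br)cc3)cs2)cc1F` stands apart; in this assay compound 2 reaches only the limit > 100000 nM, (the limit of > 100000 nM in this assay, at which 1 of the 3 values shown sits). How the core of compound 2 differs from that of compound 3 is not broken down here. The unmeasured compound 4 `Fc1ccc(/C=N/Nc2nc(-c3ccccc3)cs2)cc1F` differs from compound 2 by hydrogen in place of bromo on an aromatic carbon, the same kind of change as that from compound 3 to compound 1, though the place differs: there the carbon sat ortho to a bromo group, ortho to a large group, meta and para to methoxy groups, while here it sits para to a large group. Since the step of a 1.5-fold higher number from compound 3 to compound 1 (0.18 log units; within the scatter) stayed within the scatter, compound 4 is expected to show a step that the limit leaves unreadable from compound 2 to compound 4, resting on the limit of compound 2. Compound 4 is thus estimated at 120000 nM, between 50000 nM and 300000 nM.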

Compound 4, half-maximal inhibitory concentration: 91400 nM
Estimate against measurement, compound 4: 1.3-fold (0.12 log units) above; measured number inside the range.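

In this assay, compound 2 gives > 100000 nM, which is a limit of the assay and not a number. As far as these compounds go, the change from 4-bromophenyl to phenyl gives an at least 1.0-fold lower number from compound 2 to compound 4 (0.03 log units; that floor lies within the scatter), so the true size of this step on the core of compound 2 remains unknown, and its comparison with the earlier step stays unresolved: the same change on two cores in this assay, a 1.5-fold higher number (0.18 log units; within the scatter) from compound 3 to compound 1 and an at least 1.0-fold lower number (0.03 log units; that floor lies within the scatter) from compound 2 to compound 4; the limit leaves it open whether they differ. The two cores therefore offer no sign of conflict, but they do not show that the change carries from one core to the other with the same effect.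

The compounds shown leave open how hydrogen in place of bromo would read on a core with measured numbers on both sides. They also leave open how an amine or a carboxylic acid in place of the bromo would read.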